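From Bromo to Nitro: Estimating Compound 4

The source may hold more compounds than are shown below. What is called first, only, known or untested is meant among the compounds shown, and "the series" means these compounds.

Measured so far:
compound 1 `Cn1c(=O)[nH]c2c(cnn2-c2ccc(Br)cc2)c1=N` gives 34%
compound 2 `Cn1c(=O)[nH]c2c(cnn2-c2ccccc2Cl)c1=N` gives 7%
compound 3 `Cn1c(=O)[nH]c2c(cnn2-c2cc(Cl)ccc2Cl)c1=N` gives 1%

In an assay on membranes from brain for binding affinity to adenosine receptor A1 (Rattus norvegicus), read by radioligand binding, tested at 20 uM (on this read-out higher numbers stand for more inhibition at the one concentration tested (going by the name of the read-out) and lower numbers for less inhibition), compound 1 stands highest of the three numbers; compound 2 lies lower beyond the scatter and compound 3 lower still. Among the measured compounds shown here, the single measured step, a number 6 percentage points lower from compound 2 to compound 3 (within the scatter), concerns chloro in place of hydrogen and does not involve the change considered here. Compound 4 `Cn1c(=O)[nH]c2c(cnn2-c2ccc([N+](=O)[O-])cc2)c1=N` differs from compound 1 by nitro in place of bromo on an aromatic carbon. For the measured compounds named here, no measured step bears on a nitro group, so the direction of this change cannot be read from the data; compound 1 is the only anchor. Compound 4 is therefore expected near compound 1, with a wide range, the estimated step being a number 9 percentage points lower from compound 1 to compound 4 (within the scatter). For compound 4 the estimate is 25%, between 5% and 50%.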

Compound 4, a percentage reported as inhibition, at one concentration (the size of the read-out at that concentration, not a potency): 5%
Estimate against measurement, compound 4: 20 percentage points above; low and high end bracket the measured number.
By their numbers in this assay, from the lowest: compounds 3, 4 and 2 (each within the scatter of the next); then compound 1.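

Putting nitro in place of bromo on this aromatic carbon gives a number 29 percentage points lower from compound 1 to compound 4 (beyond the scatter) in this assay and shows that the group at this position affects the reading. Among the compounds shown here, the earlier compounds offered no step at this position, so this is the first direct comparison there. Nothing shown here bears on why the number falls. Still open, on these data alone, is whether an amine, a methoxy group or a carboxylic acid at this same place would stay near compound 1 or fall to the level of compound 4.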